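Swapping a Naphthyl Thiourea for a Dichlorophenyl Analogue

A few compounds are considered here, and "the series" means these few. Any claim that something is new, unique, unknown or untested is made for them only; others in the source may bear on it.

Of the compounds shown here, three sharing one core have been tested in a functional assay on HL-60 cells (Homo sapiens) for antiproliferative activity, with a stated time of 24 h; on this read-out higher numbers stand for weaker inhibition and lower numbers for stronger inhibition. Compound 1 `NC(=O)c1c(NC(=O)c2ccccc2F)sc2c1CCN(Cc1c(Cl)cccc1Cl)C2` gives 10300 nM in this assay. Compound 2 `NC(=O)c1c(NC(=O)c2cccc([N+](=O)[O-])c2)sc2c1CCN(Cc1ccc(Cl)cc1Cl)C2` gives 19800 nM in this assay. Compound 3 `NC(=O)c1c(NC(=O)c2ccccc2Cl)sc2c1CCN(C(=S)Nc1cccc3ccccc13)C2` gives 13400 nM in this assay, which places it as the second highest of the three numbers; its nearest neighbour is compound 1, a difference within the scatter, and its furthest is compound 2, also within the scatter. Going by the values given here, on these three numbers, then, no compound can be set apart from another.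

Compound 4 `NC(=O)c1c(NC(=O)c2ccccc2Cl)sc2c1CCN(C(=S)Nc1c(Cl)cccc1Cl)C2` has not yet been measured. It differs from compound 3 in one place: 2,6-dichlorophenyl in place of naphthalen-1-yl on an amide-type nitrogen. Among the compounds with values here, no pair of measured compounds differs in only one place, so no measured step is available to guide the size of this change. The three measured compounds, which carry different groups on the same amide-type nitrogen and elsewhere, all give numbers within the scatter of one another, and this gives no reason to expect the exchange to move the number beyond the scatter in either direction. Compound 4 is therefore expected to give about 14000 nM in this assay, with a range of 5000 nM to 40000 nM. The estimate corresponds to an expected step of a 1.0-fold higher number from compound 3 to compound 4 (0.02 log units; within the scatter).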

Compound 4, half-maximal inhibitory concentration: 3950 nM
Beside the measured number, compound 4's estimate is 3.5-fold (0.55 log units) above it; measured number outside the range, below it.
By their numbers in this assay, from the lowest: compound 4; then compounds 1, 3 and 2 (each within the scatter of the next).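

Going by these compounds alone, the exchange of naphthalen-1-yl for 2,6-dichlorophenyl on an amide-type nitrogen provides the first comparison in this assay of compounds that differ in only one place, and it gives a 3.4-fold lower number from compound 3 to compound 4 (0.53 log units; beyond the scatter). This shows that the group at this position can move the number beyond the scatter, although the step is modest, and that the second aromatic ring of naphthalen-1-yl is not required for the lower number, as compound 4 carries one six-membered aromatic ring in place of two. No measurement shown separates the loss of that ring from the arrival of the two chlorine atoms as the source of the step.

Going by these compounds, it remains open whether a plain phenyl, a 2-chlorophenyl or a 2,6-dimethylphenyl group on this nitrogen would give a number like that of compound 4 or one like that of compound 3. On these data alone, it also remains open whether the same exchange would give a step of similar size with a 2-fluorobenzoyl or 3-nitrobenzoyl group in place of the 2-chlorobenzoyl group that compound 3 and compound 4 share.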